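The compounds below may be only part of what the source reports. "The series", "measured", "known", "first", "only" and "open" are said of these compounds alone.

Of the compounds shown here, three sharing one core have been tested in a functional assay on the whole organism (strain albino) for inhibition, with Rattus norvegicus as the target, read by paw edema, with stated times of 30 min and 4 h, at a dose of 0.28 mmol/kg by the oral route; a higher number here means more inhibition at the dose given (going by the name of the read-out), a lower number less inhibition. Compound 1 `C=CCn1c(SCC(=O)Nc2ccc(/C(C)=N/O)cc2)nnc1-c1ccccc1` gives 73%, compound 2 `CCn1c(SCC(=O)Nc2ccc(/C(C)=N/O)cc2)nnc1-c1ccc(OC)c(OC)c1` gives 75%, and compound 3 `CCn1c(SCC(=O)Nc2ccc(/C(C)=N/O)cc2)nnc1-c1ccc(OC)cc1` gives 73%. Hydrogen in place of methoxy on an aromatic carbon gave a number 2 percentage points lower from compound 2 to compound 3 (within the scatter). Compound 3 thus stands level with compound 1 at the digits given, and compound 2 lies within the scatter of both. Compound 4 `CCn1c(SCC(=O)Nc2ccc(/C(C)=N/O)cc2)nnc1-c1ccccc1` differs from compound 3 by hydrogen in place of methoxy on an aromatic carbon. For the measured compounds named here, the one measured step that bears on this, hydrogen in place of methoxy on an aromatic carbon, stayed within the scatter, so no change beyond the scatter is expected here either: no change at the digits printed from compound 3 to compound 4 (within the scatter). Compound 4 is therefore estimated at 73%, with a range from 63% to 83%.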

Compound 4, a percentage reported as inhibition, in the whole organism at one dose (the size of the read-out at that dose, not a potency): 77%
For compound 4 the middle estimate is 4 percentage points below the measured one, and the stated range covers the measured number.
By their numbers in this assay, from the lowest: compounds 1, 3, 2 and 4 (each within the scatter of the next).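

In this assay, losing the methoxy at this place gives a number 4 percentage points higher from compound 3 to compound 4 (within the scatter) and the change to plain phenyl gives a number 2 percentage points higher from compound 2 to compound 4 (within the scatter) so the methoxy groups are not needed to keep this level of inhibition at this dose. The other site behaves alike, since methyl in place of vinyl gives a number 4 percentage points higher from compound 1 to compound 4 (within the scatter) and stays equally flat. Nothing measured here offers a reason for this flatness.

Still open, from the compounds shown here alone, is whether an amine or a carboxylic acid at this place on the ring would move the number beyond the scatter. The same question stands for a longer chain on the aromatic nitrogen.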